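This account rests on a few compounds, and the source may have more. Where it says the series, first, only, none or still open, it means among the compounds named here.

Measured so far:
compound 1 `O=C(O)c1cc(=O)c2c(OCCCOc3ccccc3)cccc2o1` — 35 ug/mL
compound 2 `O=C(O)c1cc(=O)c2c(OCCCCCOc3ccccc3)cccc2o1` — 17.5 ug/mL
compound 3 `O=C(O)c1cc(=O)c2ccc(OCCCOc3ccccc3)cc2o1` — 1.4 ug/mL

All three numbers come from a functional assay on ileum (Cavia porcellus) for antagonist activity, with a stated time of 30 s; on this read-out lower numbers stand for stronger inhibition and higher numbers for weaker inhibition. Compound 1 and compound 2 share one core and differ only in the side chain: 2-phenoxyethyl in place of phenoxy on a saturated chain carbon, three bonds along the chain from an oxygen on an aromatic ring. The step of a 2.0-fold lower number from compound 1 to compound 2 (0.30 log units; within the scatter) is small, so compound 1 and compound 2 are not separated by this assay. Compound 3 carries the same atoms as compound 1, joined differently; the difference between the two cores is not broken down here. Compound 3 has the lowest of the three numbers, and its gap to compound 2 and to compound 1 lies beyond the scatter in both cases.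

Compound 4 `O=C(O)c1cc(=O)c2ccc(OCCCCCOc3ccccc3)cc2o1` is not yet measured. It stands to compound 3 as compound 2 stands to compound 1: 2-phenoxyethyl in place of phenoxy on a saturated chain carbon, three bonds along the chain from an oxygen on an aromatic ring. The place of the change is the same in both pairs, so this is the same change made on the core of compound 3 rather than on the core of compound 1. Within the data shown here, the only guide to its effect is the single step from compound 1 to compound 2, which lies within the scatter. The expectation for compound 4 is therefore a step of about the same size as that one, a 1.8-fold lower number from compound 3 to compound 4 (0.24 log units; within the scatter), because the earlier step of a 2.0-fold lower number from compound 1 to compound 2 (0.30 log units; within the scatter) was itself small. Given that compound 3 gives 1.4 ug/mL, compound 4 is estimated at 0.8 ug/mL, with a plausible span from 0.3 ug/mL to 2.5 ug/mL; a single measurement cannot be expected to separate compound 4 from compound 3 with confidence.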

Compound 4, half-maximal inhibitory concentration: 0.4 ug/mL
For compound 4 the middle estimate is 2.0-fold (0.30 log units) above the measured one, and the stated range covers the measured number.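

In this assay, 2-phenoxyethyl in place of phenoxy on a saturated chain carbon, three bonds along the chain from an oxygen on an aromatic ring, gives a 3.5-fold lower number from compound 3 to compound 4 (0.54 log units; beyond the scatter), a modest step that is beyond the scatter when read alone. Set beside the earlier step, it gives no sign that the effect of this change depends on the core, and the two cores cannot be told apart on this point: the same change on two cores in this assay, a 2.0-fold lower number (0.30 log units; within the scatter) from compound 1 to compound 2 and a 3.5-fold lower number (0.54 log units; beyond the scatter) from compound 3 to compound 4, 1.8-fold (0.24 log units) apart, within the scatter of two such steps. Among these compounds, this agreement rests on only two matched pairs, one of whose steps cannot be separated from the scatter on its own, so it does not show that the change is larger on one core than on the other, nor that it would carry over to any core beyond these two.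

Going by these compounds, what happens to the number with a longer chain, or with a chain carrying an ether oxygen or an amine in place of saturated carbon, remains open, as does the effect of a chloro or methoxy group on the terminal phenyl ring. All four compounds also share the carboxylic acid, so whether the same step would hold with an ester or a tetrazole in its place cannot be said from these data.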